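The source may hold more compounds than are shown below. What is called first, only, known or untested is meant among the compounds shown, and "the series" means these compounds.

Measured so far in a functional assay on MCF7 cells (Homo sapiens) for antiproliferative activity, read by CCK-8 assay, with a stated time of 72 h; on this read-out lower numbers stand for stronger inhibition of growth and higher numbers for weaker inhibition of growth:
compound 1 `CC[C@@H]1C(=O)N(C)c2cnc(-n3ccc4cc(C(=O)NCC(C)C)ccc43)nc2N1C1CCCC1` gives 953 nM.
compound 2 `CCC1C(=O)N(C)c2cnc(-n3ccc4cc(C(=O)NCC(C)C)ccc43)nc2N1c1ccn(C)n1` gives 4810 nM.
compound 3 `CC[C@@H]1C(=O)N(C)c2cnc(-n3ccc4cc(C(=O)NC5CCCC5)ccc43)nc2N1C1CCCC1` gives 795 nM.

Compound 1 and compound 3 share one core; the change between them is cyclopentyl in place of isobutyl on an amide-type nitrogen, and it made the step of a 1.2-fold lower number from compound 1 to compound 3 (0.08 log units; within the scatter), which stays within the scatter. Compound 2 is built on a different core; how the two cores differ is not broken down here. Compound 2 stands highest of the three numbers, with compound 1 and compound 3 both beyond the scatter below it. Compound 4 `CCC1C(=O)N(C)c2cnc(-n3ccc4cc(C(=O)NC5CCCC5)ccc43)nc2N1c1ccn(C)n1` has not yet been measured in this assay. It carries the same change against compound 2 that compound 3 carries against compound 1, namely (cyclopentyl in place of isobutyl on an amide-type nitrogen), at the same place. Because the earlier step of a 1.2-fold lower number from compound 1 to compound 3 (0.08 log units; within the scatter) stayed within the scatter, only a small step is expected now: a 1.2-fold lower number from compound 2 to compound 4 (0.08 log units; within the scatter). Compound 4 is therefore estimated at 4000 nM, likely between 1800 nM and 9000 nM.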

Compound 4, concentration for 50% growth inhibition: "not active" (no number reported)
The entry for compound 4 holds no number, and the estimate cannot be compared.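

Among the compounds shown here, compound 4 is reported as "not active", without a number, so no step from compound 2 to compound 4 can be read. No evidence here accounts for this result. From the compounds shown here alone, how far cyclopentyl in place of isobutyl changes growth inhibition on the core of compound 2 stays open.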